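The source may hold more compounds than are shown below. What is called first, only, known or untested is meant among the compounds shown, and "the series" means these compounds.

Measured so far in a functional assay on T98G cells (Homo sapiens) for inhibition, read by MTT assay, with a stated time of 72 h; a lower number here means a stronger inhibitor, a higher number a weaker inhibitor:
Compound 1, `CC1(C)CC(NC(=S)NCc2ccccc2)c2cc(F)ccc2O1`: 40000 nM
Compound 2, `CC1(C)CC(NC(=S)Nc2ccc(Cl)cc2)c2cc(Br)ccc2O1`: 22000 nM

Compound 2 gives the lower of the two numbers; compound 1 sits a little higher, but the two values lie within the scatter of each other, so no order between them can be read. For the measured compounds named here, no single-change step connects the two measured compounds, so their values are taken only as they stand.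

Compound 3, `CC1(C)CC(NC(=S)NCc2ccccc2)c2cc(Br)ccc2O1`, has not been measured in this assay. Relative to compound 2 the change is benzyl in place of 4-chlorophenyl on an amide-type nitrogen. Compound 1 already carries benzyl in this place, and in this assay compound 1 gives 40000 nM, close to compound 2. The step is therefore expected to be small, roughly flat to slightly weaker and likely within the scatter; the estimated step is a 1.6-fold higher number from compound 2 to compound 3 (0.20 log units; within the scatter). For compound 3 the expected value in this assay is 35000 nM, with a range from 15000 nM to 80000 nM.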

Compound 3, half-maximal inhibitory concentration: 54000 nM
Estimate against measurement, compound 3: 1.5-fold (0.19 log units) below; the measured number falls inside the stated range.
By their numbers in this assay, from the lowest: compounds 2, 1 and 3 (each within the scatter of the next, the first and the last beyond it).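

In this assay, for the compounds shown here, the single change at this amide-type nitrogen, benzyl in place of 4-chlorophenyl with bromo held on the shared core, gives a 2.5-fold higher number from compound 2 to compound 3 (0.39 log units; beyond the scatter) as a modest step, so in this one pair the 4-chlorophenyl group gives the lower number. With benzyl held, bromo in place of fluoro on an aromatic carbon gives a 1.4-fold higher number from compound 1 to compound 3 (0.13 log units; within the scatter) and no order can be read for this swap. No measured evidence is available to explain either step.

Going by these compounds, whether the 4-chlorophenyl advantage holds with fluoro on the core remains open. Also open, on these data alone, is how an unsubstituted phenyl, a 4-methoxyphenyl or a longer chain such as 2-phenylethyl on this nitrogen would read against these two groups.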